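Anilide series on Jurkat cells: benzoyl in place of chloropyridinyl

The source may report more compounds than this note shows. Statements on the series, on what has been measured and on what is new or still open speak of the compounds shown alone.

Measured so far:
compound 1 `O=C(Nc1cc(C(F)(F)F)ccc1NC1CCCCC1)c1cccnc1` — "not active" (no number reported)
compound 2 `O=C(Nc1cc(C(F)(F)F)ccc1Nc1ccc(Br)cc1)c1cccnc1Cl` — 20600 nM
compound 3 `CCN(CC)c1ccc(C(F)(F)F)cc1NC(=O)c1cccnc1` — "not active" (no number reported)

Among the compounds with values here, in a functional assay on Jurkat cells (Homo sapiens) for cytotoxicity, read by MTT assay, with a stated time of 48 h (on this read-out lower numbers stand for stronger inhibition and higher numbers for weaker inhibition), compound 2 gives 20600 nM, the only number in the set; compound 1 and compound 3 return no number at all. Compound 2 is thus the sole reference point, and its value is weak. Within the data shown here, no two measured compounds differ in a single place, so no measured step exists. Compound 4 `O=C(Nc1cc(C(F)(F)F)ccc1Nc1ccc(Br)cc1)c1ccccc1` differs from compound 2 in one place: phenyl in place of 2-chloropyridin-3-yl on a carbonyl carbon. With nothing measured to rest on, the expected step in this assay is a 1.2-fold higher number from compound 2 to compound 4 (0.08 log units; within the scatter), within the scatter and without a favoured direction. Compound 4 is expected near 25000 nM, ranging from 8000 nM to 80000 nM, with a real chance that only a limit is reported.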

Compound 4, half-maximal inhibitory concentration: 33800 nM
The estimate for compound 4 lay 1.4-fold (0.13 log units) below the measured number; the range from low to high includes it.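

In this assay, phenyl in place of 2-chloropyridin-3-yl on a carbonyl carbon gives a 1.6-fold higher number from compound 2 to compound 4 (0.22 log units; within the scatter) and so cannot be told apart from the parent. Within the data shown here, the ring nitrogen and the chlorine are therefore not required for a measurable number in this pair, which is the first direct reading at this position. No measurement at hand bears on the reason for this result. Still open, going by these compounds, is whether an amine or a carboxylic acid on this carbonyl carbon would give a number clearly apart from these two.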